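Ester group variation at the carbonyl-bound oxygen

A few compounds are considered here, and "the series" means these few. Any claim that something is new, unique, unknown or untested is made for them only; others in the source may bear on it.

In a functional assay on isolated protein for inhibition of Glucose-dependent insulinotropic receptor (Rattus norvegicus), read by HTRF and cAMP accumulation (on this read-out higher numbers stand for an effect only at larger amounts of compound and lower numbers for an effect already at smaller amounts), compound 1 `Cc1nc(S(C)(=O)=O)ccc1Oc1ncnc(OC2CCN(C(=O)OC3CCC3)CC2)c1F` gives 167 nM. Compound 2 `Cc1nc(S(C)(=O)=O)ccc1Oc1ncnc(OC2CCN(C(=O)OC(C)(C)CF)CC2)c1F` gives 138 nM in this assay, and compound 3 `Cc1nc(S(C)(=O)=O)ccc1Oc1ncnc(OC2CCN(C(=O)OC(C)F)CC2)c1F` gives 315 nM, the highest of the three numbers. Among the measured compounds shown here, two measured steps bear on the ester group: a 1.9-fold higher number from compound 1 to compound 3 (0.28 log units; within the scatter), and a 2.3-fold higher number from compound 2 to compound 3 (0.36 log units; beyond the scatter); the third, a 1.2-fold lower number from compound 1 to compound 2 (0.08 log units; within the scatter), adds little. Compound 4 `Cc1nc(S(C)(=O)=O)ccc1Oc1ncnc(OC2CCN(C(=O)O[C@H](C)CF)CC2)c1F` carries the change (1-(fluoromethyl)ethyl in place of 1-fluoroethyl on an oxygen next to a carbonyl group). The entering group sits between the groups of compound 3 and compound 2 in its count of carbon atoms, so a partial return toward the number of compound 2 is expected: a 1.6-fold lower number from compound 3 to compound 4 (0.20 log units; within the scatter), a modest lowering. For compound 4 in this assay the expected value is 200 nM, with a range from 100 nM to 400 nM.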

Compound 4, half-maximal effective concentration: 1520 nM
For compound 4 the middle estimate is 7.6-fold (0.88 log units) below the measured one; measured number outside the range, above it.
By their numbers in this assay, from the lowest: compounds 2, 1 and 3 (each within the scatter of the next, the first and the last beyond it); then compound 4.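

Among the compounds shown here, at this place, on an oxygen next to a carbonyl group, the series is far less tolerant than the earlier compounds suggested: this assay shows a 4.8-fold higher number from compound 3 to compound 4 (0.68 log units; beyond the scatter), an 11-fold higher number from compound 2 to compound 4 (1.04 log units; beyond the scatter) and a 9.1-fold higher number from compound 1 to compound 4 (0.96 log units; beyond the scatter). The number does not follow the carbon count of the group, since 1-(fluoromethyl)ethyl falls between the groups of compound 3 and compound 2 in that count but its number lies outside both. No measurement available here accounts for this result.

Going by these compounds, whether the defined stereocentre of compound 4 contributes remains open, as does whether the opposite mirror-image form of 1-(fluoromethyl)ethyl, an isopropyl group without fluorine or a longer chain would restore the number.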